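The compounds below may be only part of what the source reports. "The series", "measured", "known", "first", "only" and "open" are said of these compounds alone.

Compound 1 `c1ccc(-c2nccs2)c(OCC2=NCCN2)c1` in a functional assay for activation of Alpha-1D adrenergic receptor (Homo sapiens), read by calcium flux (a higher number here means that more compound is needed for the effect, a lower number that less compound is needed), gives 31.6 nM. Compound 2 `Cc1ccoc1-c1ccccc1OCC1=NCCN1` in this assay gives only a limit, < 100000 nM. Compound 3 `Cc1cc(-c2ccccc2OCC2=NCCN2)sn1` is not yet measured.

Compound 2 stands at the limit of the assay, so its position relative to compound 1 is known only as a step that the limit leaves unreadable from compound 1 to compound 2, a step whose size cannot be read (the limit of < 100000 nM in this assay, at which 1 of the 2 values shown sits). Compound 3 differs from compound 2 by 3-methyl-1,2-thiazol-5-yl in place of 3-methylfuran-2-yl on an aromatic carbon. Among the compounds with values here, only one measured step bears on this change, and it is the unreadable one from compound 1 to compound 2, so the direction and size of the move in this assay from compound 2 to compound 3 cannot be inferred from anything firmer than the span between the two known compounds. Compound 3 is therefore expected to give about 5000 nM, somewhere between 300 nM and 100000 nM, which would mean an estimated step that the limit leaves unreadable from compound 2 to compound 3.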

Compound 3, half-maximal effective concentration: < 100000 nM
Compound 3 was reported as a limit; the forecaster's own chance of this, stated with the estimate: 40%; the middle value lies beyond the limit too.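

Compound 3, like compound 2, gives only a limit in this assay, so no new step can be read among compound 1, compound 2 and compound 3: the limit of < 100000 nM in this assay, at which 2 of the 3 values shown sit.

The compounds shown leave open how far compound 2 and compound 3 stand from compound 1, and whether 3-methyl-1,2-thiazol-5-yl and 3-methylfuran-2-yl differ at all in this assay.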